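Sulfonamide nitrogen: cyclopentyl replaced by isobutyl

A few compounds are considered here, and "the series" means these few. Any claim that something is new, unique, unknown or untested is made for them only; others in the source may bear on it.

Working notes on the series. For the measured compounds named here, compound 2 `CC[C@@H]1C(=O)N(C)c2cnc(Nc3ccc(S(=O)(=O)NC4CCCC4)cc3)nc2N1C1CCCC1` is the reference point: in a functional assay on A549 cells (Homo sapiens) for antiproliferative activity, read by CCK-8 assay, with a stated time of 72 h (on this read-out higher numbers stand for weaker inhibition of growth and lower numbers for stronger inhibition of growth), compound 2 gives 1150 nM, the lowest of the two numbers so far. Compound 3 `CCC1C(=O)N(C)c2cnc(Nc3ccc(S(=O)(=O)NC)cc3)nc2N1c1ccn(C)n1` gives 12600 nM in this assay, a gap beyond the scatter; compound 3 differs from compound 2 in more than one place, so nothing about any single change follows from that pair. Compound 1 `CC[C@@H]1C(=O)N(C)c2cnc(-n3ccc4cc(F)ccc43)nc2N1C1CCCC1` was reported in this assay as "not active" (no number reported), with no number.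

Compound 4 `CC[C@@H]1C(=O)N(C)c2cnc(Nc3ccc(S(=O)(=O)NCC(C)C)cc3)nc2N1C1CCCC1` differs from compound 2 by isobutyl in place of cyclopentyl on a sulfonamide nitrogen. Going by the values given here, no measured pair differs at one place, so the size of this step is untested. For compound 4 only a small step in this assay is expected, a 1.4-fold higher number from compound 2 to compound 4 (0.14 log units; within the scatter), toward a slightly higher number or none beyond the scatter. Compound 4 is estimated at 1600 nM, within 600 nM to 4500 nM.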

Compound 4, concentration for 50% growth inhibition: 750 nM
Beside the measured number, compound 4's estimate is 2.1-fold (0.33 log units) above it; low and high end bracket the measured number.
By their numbers in this assay, from the lowest: compounds 4 and 2 (each within the scatter of the next); then compound 3.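

In this assay, for the compounds shown here, isobutyl in place of cyclopentyl on the sulfonamide nitrogen gives the first single-place step (a 1.5-fold lower number from compound 2 to compound 4 (0.19 log units; within the scatter)). At this position, an open branched chain therefore reads level with the five-membered carbon ring, so this ring is not needed to hold the number in compound 4. No measurement on hand offers an explanation for this result. On these data alone, it remains open whether a longer chain, a carboxylic acid or an amine on this nitrogen would stay at the same level.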